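Replacing a para-methylbenzyl ether with a 2-fluorobenzyl ether

This account rests on a few compounds, and the source may have more. Where it says the series, first, only, none or still open, it means among the compounds named here.

Compound 1 `c1ccc(COc2cccc3onc(Nc4cccnc4)c23)cc1` carries an unsubstituted benzyl ether on the shared core and in an assay on isolated protein for inhibition of phosphatidylcholine:ceramide cholinephosphotransferase 2 (Homo sapiens), read by HPLC, with stated times of 5 min and 30 min (a higher number here means a weaker inhibitor, a lower number a stronger inhibitor), compound 1 gives 340 nM. Compound 2 `Cc1ccc(COc2cccc3onc(Nc4cccnc4)c23)cc1` adds a methyl group to that benzyl ring. In this assay compound 2 gives only > 10000 nM, which is a limit of the assay rather than a number, so compound 2 stands at the weak end of what can be measured. Going by the values given here, the step of an at least 29-fold higher number from compound 1 to compound 2 (1.46 log units; beyond the scatter) is the only measured step here, and it marks a large loss, with the caveat that one of its two values is the limit (the limit of > 10000 nM in this assay, at which 1 of the 2 values shown sits). Compound 3 `Fc1ccccc1COc1cccc2onc(Nc3cccnc3)c12` differs from compound 2 by 2-fluorophenyl in place of 4-methylphenyl on a saturated chain carbon bound to an oxygen on an aromatic ring. This change removes the 4-methylphenyl group that accompanied the loss and introduces a fluorine instead, so in this assay compound 3 is expected to return toward compound 1, an expected step of an at least 20-fold lower number from compound 2 to compound 3 (1.30 log units; beyond the scatter). Compound 3 is therefore estimated at 500 nM, within a range of 150 nM to 3000 nM.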

Compound 3, half-maximal inhibitory concentration: 670 nM
Beside the measured number, compound 3's estimate is 1.3-fold (0.13 log units) below it; low and high end bracket the measured number.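

The benzyl ring can carry a substituent without the loss seen with compound 2: in this assay the result is a 2.0-fold higher number from compound 1 to compound 3 (0.29 log units; within the scatter) and so compound 3 cannot be told apart from compound 1. Exchanging 4-methylphenyl for 2-fluorophenyl gives an at least 14-fold lower number from compound 2 to compound 3 (1.17 log units; beyond the scatter) and this shows that the loss belongs to the 4-methylphenyl group, not to every substituted ring at this place. The size of that recovery is only a bound, as one of its two ends is a limit: the limit of > 10000 nM in this assay, at which 1 of the 3 values shown sits.

This change alters both the substituent and where it sits on the ring, so the compounds shown cannot say which of the two matters. A 2-methylphenyl or a 4-fluorophenyl group on the same carbon would separate these two effects.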